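Swapping Cyclopropylmethyl for 3,4-Dichlorophenyl in a Binding Series

The source may hold more compounds than are shown below. What is called first, only, known or untested is meant among the compounds shown, and "the series" means these compounds.

Three compounds built on one shared core were compared in an assay on cells for displacement of a labelled ligand from corticotropin-releasing factor receptor 1 (Homo sapiens), with a stated time of 100 min; on this read-out lower numbers stand for stronger inhibition and higher numbers for weaker inhibition. Compound 1 `CCCCN(CC)Cc1c(C(F)(F)F)nc2n(-c3c(C)cc(C)cc3C)c(Cl)cn12` gives 78 nM, compound 2 `C=C(C)CN(CC)Cc1c(C(F)(F)F)nc2n(-c3c(C)cc(C)cc3C)c(Cl)cn12` gives 67 nM, and compound 3 `CCN(CCC1CC1)Cc1c(C(F)(F)F)nc2n(-c3c(C)cc(C)cc3C)c(Cl)cn12` gives 13 nM, the lowest of the three numbers. The step of a 1.2-fold lower number from compound 1 to compound 2 (0.07 log units; within the scatter) stays within the scatter, whereas a 6.0-fold lower number from compound 1 to compound 3 (0.78 log units; beyond the scatter) and a 5.2-fold lower number from compound 2 to compound 3 (0.71 log units; beyond the scatter) both set compound 3 apart from its two neighbours in this assay.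

Compound 4 `CCN(Cc1ccc(Cl)c(Cl)c1)Cc1c(C(F)(F)F)nc2n(-c3c(C)cc(C)cc3C)c(Cl)cn12` differs from compound 3 by 3,4-dichlorophenyl in place of cyclopropylmethyl on a saturated chain carbon bound to an amine nitrogen. Within the data shown here, no measured step involves an aromatic group at this place; the known steps only concern exchanges among small saturated or unsaturated chains, and those that reached beyond the scatter all led toward compound 3. With nothing directly comparable, the direction of the new step is uncertain, and a modest weakening from the best number in the set is the more likely outcome. Compound 4 is therefore expected to give 35 nM in this assay, with an estimated range from 7 nM to 180 nM. The expected step is a 2.7-fold higher number from compound 3 to compound 4 (0.43 log units; beyond the scatter), likely beyond the scatter but not large.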

Compound 4, inhibition constant: 580 nM
Compound 4: middle estimate off by 17-fold (1.22 log units), on the low side, and the stated range ends below it.
By their numbers in this assay, from the lowest: compound 3; then compounds 2 and 1 (each within the scatter of the next); then compound 4.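

Among these compounds, at this place, on a saturated chain carbon bound to an amine nitrogen, an aromatic group appears for the first time, and in this assay 3,4-dichlorophenyl in place of cyclopropylmethyl gives a 45-fold higher number from compound 3 to compound 4 (1.65 log units; beyond the scatter). Set against the other two chains, the same group gives an 8.7-fold higher number from compound 2 to compound 4 (0.94 log units; beyond the scatter) and a 7.4-fold higher number from compound 1 to compound 4 (0.87 log units; beyond the scatter), so compound 4 has the highest number of the four, and every step to it lies beyond the scatter. Among the compounds shown here, the earlier compounds showed only that the number could fall through a change here, whereas this result shows that a change here can also raise it, and by more than any earlier step lowered it.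

Going by these compounds, whether the rise belongs to the ring itself or to its two chlorines stays open, and an unsubstituted phenyl group would separate the two. Nothing available bears on the reason for this rise.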